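Working notes: cytotoxicity across the shared series

The source may report more compounds than this note shows. Statements on the series, on what has been measured and on what is new or still open speak of the compounds shown alone.

Compound 1 `COc1ccc(-c2cnc(NC(=O)c3ccc(Br)cc3)n2C)cc1` gives in a toxicity assay on THP-1 cells (Homo sapiens) for inhibition (on this read-out lower numbers stand for higher toxicity in this test and higher numbers for lower toxicity in this test), a value of > 100000 nM, which is a limit of the assay and not a number. Compound 2 `Cn1c(-c2ccccc2)cnc1NC(=O)c1ccc(Cl)cc1` likewise reaches only a limit in this assay, > 100000 nM. Compound 3 `Cn1c(-c2ccccc2)cnc1NC(=O)c1ccc(Br)cc1` also stands at a limit in this assay, > 100000 nM. The two measured steps, a step that the two limits leave unreadable from compound 1 to compound 3 and a step that the two limits leave unreadable from compound 2 to compound 3, cannot be given a size because every value shown sits at the same point, (the limit of > 100000 nM in this assay, at which 3 of the 3 values shown sit). Compound 4 `COc1ccc(-c2cnc(NC(=O)c3ccc(C)cc3)n2C)cc1` is the next member and differs from compound 1 by methyl in place of bromo on an aromatic carbon. Both measured steps bear on it in that they also exchange substituents on an aromatic carbon of the series, yet neither lets a size be read, so they give no ground for expecting a step beyond the scatter in this assay. The step that the limit leaves unreadable from compound 1 to compound 4 is therefore expected to be flat. Compound 4 is expected to give about 150000 nM in this assay, within 60000 nM to 400000 nM, and most likely again only as a limit.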

Compound 4, half-maximal cytotoxic concentration: > 100000 nM
Compound 4: only a limit was reported (the forecaster's own chance of this, stated with the estimate: 85%); the middle value does not contradict the limit.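

No step can be read from compound 1 to compound 4, as both stand at the same limit of the assay, which is not a number: the limit of > 100000 nM in this assay, at which 4 of the 4 values shown sit.
From the compounds shown here alone, whether any compound of this series gives a readable value in this assay and what size its substituent exchanges would then have stays open.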